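Replacing naphthalen-1-yl with 2-bromo-5-methoxyphenyl

The source may report more compounds than this note shows. Statements on the series, on what has been measured and on what is new or still open speak of the compounds shown alone.

Compound 2 `CCOC(=O)C(C(=O)c1ccc(OC)cc1)C(NC(C)=O)c1cccc2ccccc12` gives 99.2% in an ADME assay on Vero cells (Chlorocebus sabaeus) for cytotoxicity, read by MTT assay, tested at 25 uM (on this read-out lower numbers stand for a stronger effect and higher numbers for a weaker effect at the one concentration tested), and compound 1 `CCOC(=O)C(C(=O)c1ccc(OC)cc1)C(NC(C)=O)c1ccc(C(C)(C)C)cc1` gives 94.5% in this assay; the two lie within the scatter of each other, so neither stands apart. Compound 3 `CCOC(=O)C(C(=O)c1ccc(OC)cc1)C(NC(C)=O)c1cc(OC)ccc1Br` differs from compound 2 as follows: 2-bromo-5-methoxyphenyl in place of naphthalen-1-yl on a saturated chain carbon bound to an amide-type nitrogen and a saturated chain carbon. Among the compounds with values here, no measured pair covers this exact exchange. Within the data shown here, the only step at this place, a number 4.7 percentage points higher from compound 1 to compound 2 (within the scatter), changed little, so the expected step of a number 3.2 percentage points lower from compound 2 to compound 3 (within the scatter) is estimated to stay within the scatter. Compound 3 is therefore expected to give about 96% in this assay, between 86% and 100%.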

Compound 3, a percentage reported as activity, at one concentration (the size of the read-out at that concentration, not a potency): 96.3%
For compound 3 the middle estimate is 0.3 percentage points below the measured one; measured number inside the range.
By their numbers in this assay, from the lowest: compounds 1, 3 and 2 (each within the scatter of the next).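

In this assay, the step to 2-bromo-5-methoxyphenyl reads as a number 2.9 percentage points lower from compound 2 to compound 3 (within the scatter) and, from the other side, as a number 1.8 percentage points higher from compound 1 to compound 3 (within the scatter). At this position, then, a single ring bearing bromine and a methoxy group gives a number that cannot be told apart from those of the naphthalen-1-yl and 4-(tert-butyl)phenyl compounds. Nothing available explains this closeness. From the compounds shown here alone, all three compounds carry an aromatic ring of carbon only at this place, so the effect of an amine, a carboxylic acid or a longer chain there remains open.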